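A few compounds are considered here, and "the series" means these few. Any claim that something is new, unique, unknown or untested is made for them only; others in the source may bear on it.

Measured so far in an ADME assay on HEK293 cells (Homo sapiens) for cytotoxicity, read by MTT assay, with a stated time of 48 h; on this read-out higher numbers stand for weaker inhibition and lower numbers for stronger inhibition:
compound 1 `CCS(=O)(=O)Nc1ccc(NC(=O)c2ccc(Cl)c([N+](=O)[O-])c2)cc1C` gives 144000 nM;
compound 2 `COc1cc(NC(=O)c2ccc(Cl)c([N+](=O)[O-])c2)ccc1NS(C)(=O)=O` gives 164000 nM;
compound 3 `CCS(=O)(=O)Nc1ccc(NC(=O)c2ccc(Cl)cc2)cc1OC` gives only a limit of the assay, > 250000 nM.

Compound 3 therefore stands apart from the other two on the numbers shown, since its entry is a limit rather than a value, (the limit of > 250000 nM in this assay, at which 1 of the 3 values shown sits). Compound 4 `CCS(=O)(=O)Nc1ccc(NC(=O)c2ccc(Cl)c([N+](=O)[O-])c2)cc1OC` is compound 3 with nitro in place of hydrogen on an aromatic carbon. Among the compounds with values here, no measured pair differs by this change alone, so the size of the step in this assay is open. Still, compound 1 with 144000 nM and compound 2 with 164000 nM both carry the nitro group and report numbers, so compound 4 is expected to land near them. For compound 4 the estimate in this assay is 155000 nM, within 90000 nM to 260000 nM. This estimate means an expected step of an at least 1.6-fold lower number from compound 3 to compound 4 (0.20 log units; that floor lies within the scatter).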

Compound 4, half-maximal inhibitory concentration: 63700 nM
Compound 4: middle estimate off by 2.4-fold (0.39 log units), on the high side, and the stated range ends above it.
By their numbers in this assay, from the lowest: compound 4; then compounds 1 and 2 (each within the scatter of the next). At a limit, above all of these: compound 3.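

In this assay, within the data shown here, nitro in place of hydrogen on an aromatic carbon, ortho to a chloro group, gives an at least 3.9-fold lower number from compound 3 to compound 4 (0.59 log units; beyond the scatter), the first direct reading of this change. That step is only a floor, since compound 3 stands at a limit: the limit of > 250000 nM in this assay, at which 1 of the 4 values shown sits. With nitro present, the other two single changes can also be read: methyl in place of hydrogen on the chain carbon bound to the sulfonyl sulfur gives a 2.6-fold lower number from compound 2 to compound 4 (0.41 log units; beyond the scatter), and methoxy in place of methyl gives a 2.3-fold lower number from compound 1 to compound 4 (0.35 log units; beyond the scatter).

On these data alone, the full size of the nitro step stays open. So does whether an amine or a nitrile on that carbon would lower the number in the same way.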